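Swapping Fluoro for Chloro in a Paw Edema Series

This account rests on a few compounds, and the source may have more. Where it says the series, first, only, none or still open, it means among the compounds named here.

Three compounds share one core: compound 1 `Clc1ccc(-c2nnc(-c3cn(-c4ccccc4)nc3-c3ccccc3)o2)cc1`, compound 2 `Cc1ccc(-c2nn(-c3ccccc3)cc2-c2nnc(-c3ccc(Cl)cc3)o2)cc1` and compound 3 `Fc1ccc(-c2nn(-c3ccccc3)cc2-c2nnc(-c3ccc(Cl)cc3)o2)cc1`. In a functional assay on the whole organism for inhibition, with Rattus norvegicus as the target, read by paw edema, with stated times of 1 h and 2 h (a lower number here means that less compound is needed, a higher number that more compound is needed for the effect), compound 1 gives "not determined" (no result reported), and compound 2 gives "not determined" (no result reported). Compound 3 thus stands alone with a number; in this assay compound 3 gives 183 mg/kg. The next compound, compound 4 `Clc1ccc(-c2nnc(-c3cn(-c4ccccc4)nc3-c3ccc(Cl)cc3)o2)cc1`, differs from compound 3 in one place, (chloro in place of fluoro on an aromatic carbon), chloro in place of fluoro on an aromatic carbon, para to a large group. Among the measured compounds shown here, no measured pair shows what this exchange does in this assay, so there is no step to lean on. The step of a 1.1-fold lower number from compound 3 to compound 4 (0.06 log units; within the scatter) is expected to stay within the usual scatter. The estimate for compound 4 in this assay is 160 mg/kg, with a range from 80 mg/kg to 350 mg/kg.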

Compound 4, dose for half-maximal effect: 199 mg/kg
Compound 4: the middle estimate sits 1.2-fold (0.09 log units) below what was measured, and the stated range covers the measured number.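

In this assay, among the compounds shown here, the exchange gives a 1.1-fold higher number from compound 3 to compound 4 (0.04 log units; within the scatter), the first step with a number on both sides. At this place, para to a large group, 4-fluorophenyl and 4-chlorophenyl therefore cannot be told apart in this read-out. Nothing available explains this result. Going by these compounds, whether an amine, a carboxylic acid or a longer chain at this place would give a step beyond the scatter remains open. On these data alone, how the values for compound 1 and compound 2 would compare with these two also remains open, as neither has a number.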